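Methylsulfonyl on the piperazine nitrogen of compound 2

This account rests on a few compounds, and the source may have more. Where it says the series, first, only, none or still open, it means among the compounds named here.

Measured compounds:
- Compound 1, `CC(C)(C)OC(=O)N1CCN(C(=O)CCCc2cn(Cc3ccccc3)c3ccccc23)CC1`: 38.2%
- Compound 2, `O=C(CCCc1cn(Cc2ccccc2)c2ccccc12)N1CCNCC1`: 95.4%

Of the compounds shown here, two have been measured in an assay on cells for inhibition of Polyunsaturated fatty acid 5-lipoxygenase (Rattus norvegicus), tested at 5 uM; on this read-out higher numbers stand for more inhibition at the one concentration tested (going by the name of the read-out) and lower numbers for less inhibition. Compound 1, `CC(C)(C)OC(=O)N1CCN(C(=O)CCCc2cn(Cc3ccccc3)c3ccccc23)CC1`, carries a tert-butoxycarbonyl group on the ring nitrogen and gives 38.2%. Compound 2, `O=C(CCCc1cn(Cc2ccccc2)c2ccccc12)N1CCNCC1`, has a hydrogen in its place and gives 95.4%. Compound 2 therefore stands highest of the two numbers, and its step from compound 1 is beyond the scatter: a number 57.2 percentage points higher from compound 1 to compound 2 (beyond the scatter).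

Compound 3, `CS(=O)(=O)N1CCN(C(=O)CCCc2cn(Cc3ccccc3)c3ccccc23)CC1`, is not yet measured. Its difference from compound 2 is methylsulfonyl in place of hydrogen on an amine nitrogen in a ring. For the measured compounds named here, only one measured step bears on this change: the step of a number 57.2 percentage points higher from compound 1 to compound 2 (beyond the scatter), which took a group away from the same ring nitrogen and raised the read-out by a large amount. Compound 3 puts a group back onto that nitrogen, though a smaller one than tert-butoxycarbonyl. Going by the values given here, a step downward is therefore expected, though with only one comparison its size is uncertain; the expected step is a number 40.4 percentage points lower from compound 2 to compound 3 (beyond the scatter). For compound 3 the estimated value in this assay is 55%, with a range from 25% to 85%.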

Compound 3, a percentage reported as inhibition, at one concentration (the size of the read-out at that concentration, not a potency): 23.9%
Compound 3: the middle estimate sits 31.1 percentage points above what was measured; the whole stated range lies above it.
By their numbers in this assay, from the lowest: compound 3; then compound 1; then compound 2.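

In this assay, the free ring nitrogen of compound 2 now stands out against two different groups on that same atom, not just one, and methylsulfonyl brings a large loss (a number 71.5 percentage points lower from compound 2 to compound 3 (beyond the scatter)). The earlier drop therefore did not belong to tert-butoxycarbonyl alone, and a group with only 4 heavy atoms does not recover the number: it goes lower still (a number 14.3 percentage points lower from compound 1 to compound 3 (beyond the scatter)). Nothing measured here explains why either group goes with less inhibition.

These three compounds show only the hydrogen and two groups on this nitrogen, so they cannot say whether every substituent there brings a loss or only those that, like these two, join through a carbonyl or a sulfonyl. A plain methyl or a benzyl on the nitrogen would test this, while an acetyl would sit closer to compound 1, and each would need reading in this assay, which gives inhibition at one concentration and not a potency.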